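This account rests on a few compounds, and the source may have more. Where it says the series, first, only, none or still open, it means among the compounds named here.

Measured in a functional assay on HepG2 cells (Homo sapiens) for cytotoxicity, read by sulforhodamine B assay, with a stated time of 24 h; on this read-out higher numbers stand for weaker inhibition and lower numbers for stronger inhibition:
compound 1 (`O=C1Nc2ccc(S(=O)(=O)N3CCOCC3)cc2/C1=N/c1cccc(C(F)(F)F)c1`): 14300 nM
compound 2 (`O=C1Nc2ccc(S(=O)(=O)N3CCOCC3)cc2/C1=N/c1ccc(/N=C2\C(=O)Nc3ccc(S(=O)(=O)N4CCOCC4)cc32)cc1`): 8840 nM

Compound 1 at 14300 nM and compound 2 at 8840 nM lie within the scatter of each other, so neither stands apart. Compound 3 (`O=C1Nc2ccc(S(=O)(=O)N3CCOCC3)cc2/C1=N/Nc1ccccc1`) has not yet been measured. Its difference from compound 1 is anilino in place of 3-(trifluoromethyl)phenyl on a double-bonded nitrogen. Among the measured compounds shown here, no measured pair shows this change, so no step beyond the scatter is expected in this assay, and no direction is favoured. The estimated step, expected to stay within the scatter, is a 1.2-fold lower number from compound 1 to compound 3 (0.08 log units; within the scatter) and no more. For compound 3 the expected value is 12000 nM (4000 nM to 35000 nM).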

Compound 3, half-maximal inhibitory concentration: 15600 nM
Estimate against measurement, compound 3: 1.3-fold (0.11 log units) below; low and high end bracket the measured number.
By their numbers in this assay, from the lowest: compounds 2, 1 and 3 (each within the scatter of the next).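

In this assay, anilino in place of 3-(trifluoromethyl)phenyl on a double-bonded nitrogen gives a 1.1-fold higher number from compound 1 to compound 3 (0.04 log units; within the scatter) and so leaves the read-out within the scatter. At this position, then, the change from 10 heavy atoms with three fluorines to 7 with one nitrogen, adding a hydrogen-bond donor and acceptor, moves nothing measurable here. No supporting data bear on why this exchange is silent.

On these data alone, whether an amine, a carboxylic acid or a longer alkyl chain at this position would shift the number beyond the scatter remains open.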